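This account rests on a few compounds, and the source may have more. Where it says the series, first, only, none or still open, it means among the compounds named here.

Series notes. Compound 1 `O=C(Nc1c(C(O)(C(F)(F)F)C(F)(F)F)ccc2ccccc12)c1ccccc1` and compound 2 `O=C(Nc1c(C(O)(C(F)(F)F)C(F)(F)F)ccc2ccccc12)c1cccc(Cl)c1` share one core and differ only in the group on the carbonyl carbon. In an assay on LtK cells with ATP-sensitive inward rectifier potassium channel 11 (Homo sapiens) as the target (on this read-out higher numbers stand for an effect only at larger amounts of compound and lower numbers for an effect already at smaller amounts), compound 1 gives 44 nM, and compound 2 gives 98 nM. The single measured step, a 2.2-fold higher number from compound 1 to compound 2 (0.35 log units; beyond the scatter), leaves compound 2 at the higher of the two numbers shown, with compound 1 as its nearest neighbour. Compound 3 `O=C(Nc1c(C(O)(C(F)(F)F)C(F)(F)F)ccc2ccccc12)c1cccs1` exchanges the whole aromatic ring on that carbonyl carbon: thiophen-2-yl in place of 3-chlorophenyl on a carbonyl carbon. Within the data shown here, no measured pair covers a six-membered carbon ring against a five-membered ring with one hetero atom, so only a 2.2-fold higher number from compound 1 to compound 2 (0.35 log units; beyond the scatter) bears on the step, and it bears indirectly: the chlorine-bearing group is the one that leaves. A return toward the number of compound 1 is therefore expected, because a 2.2-fold higher number from compound 1 to compound 2 (0.35 log units; beyond the scatter) runs the other way, while the ring exchange itself adds uncertainty. For compound 3 in this assay the estimate is 55 nM, within 20 nM to 150 nM, meaning a 1.8-fold lower number from compound 2 to compound 3 (0.25 log units; within the scatter) is expected.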

Compound 3, half-maximal effective concentration: 12 nM
Compound 3: the middle estimate sits 4.6-fold (0.66 log units) above what was measured; measured number outside the range, below it.
By their numbers in this assay, from the lowest: compound 3; then compound 1; then compound 2.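

In this assay, the group on the carbonyl carbon can move the number down as well as up: thiophen-2-yl in place of 3-chlorophenyl gives an 8.2-fold lower number from compound 2 to compound 3 (0.91 log units; beyond the scatter) and thiophen-2-yl in place of phenyl gives a 3.7-fold lower number from compound 1 to compound 3 (0.56 log units; beyond the scatter) in the same direction. The drop is therefore not just the loss of the chlorine, as the five-membered ring with one hetero atom goes with a lower number than both six-membered carbon rings shown. Nothing available gives a reason for this difference.

From the compounds shown here alone, whether the lower number follows the sulfur or the five-membered ring remains open, and furan-2-yl or thiophen-3-yl on the same carbonyl carbon would bear on that. Also open, going by these compounds, is whether the step seen with chloro on the phenyl ring carries over to a chloro-substituted thiophen-2-yl.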